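This account rests on a few compounds, and the source may have more. Where it says the series, first, only, none or still open, it means among the compounds named here.

Compound 1 `COc1cc(N(CC2CC2)c2ccc(Cl)c(Cl)c2)cnc1C(=O)[C@H]1C[C@@H]1C(=O)O` has been tested in an assay for inhibition of leukotriene C4 synthase (Homo sapiens), read by LC-MS, with stated times of 15 min and 30 min (on this read-out lower numbers stand for stronger inhibition and higher numbers for weaker inhibition), where compound 1 gives 4.94 nM. Among the three measured compounds this number is the second highest. Compound 3 `COc1cc(N(CC(C)C)c2cccc(C(F)(F)F)c2)cnc1C(=O)[C@H]1C[C@@H]1C(=O)O` gives 4.74 nM, a number lying within the usual scatter of the number for compound 1, so the two cannot be ranked. Compound 2 `COc1cc(N(CC2CC2)c2ccc(Cl)c3ccccc23)cnc1C(=O)CCCC(=O)O` gives 109 nM, a number beyond the scatter and the highest of the three. Compound 4 `COc1cc(N(CC2CC2)c2cc(Cl)c(F)cc2F)cnc1C(=O)[C@H]1C[C@@H]1C(=O)O` is not yet measured; it differs from compound 1 in one place: 5-chloro-2,4-difluorophenyl in place of 3,4-dichlorophenyl on a nitrogen on an aromatic ring. For the measured compounds named here, no measured pair shows this kind of change, so in this assay the expected step is small, a 1.4-fold higher number from compound 1 to compound 4 (0.15 log units; within the scatter), with no direction beyond the scatter assumed. Compound 4 is therefore estimated at 7 nM, within 2 nM to 25 nM.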

Compound 4, half-maximal inhibitory concentration: 1.97 nM
The estimate for compound 4 lay 3.6-fold (0.55 log units) above the measured number; the measured number lies below the stated range.
By their numbers in this assay, from the lowest: compound 4; then compounds 3 and 1 (each within the scatter of the next); then compound 2.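

The aryl group on this nitrogen is a position where the halogen pattern matters: in this assay, 5-chloro-2,4-difluorophenyl in place of 3,4-dichlorophenyl gives a 2.5-fold lower number from compound 1 to compound 4 (0.40 log units; beyond the scatter) and so a modest gain in inhibition. This rests on a single pair of compounds, so it is no general rule. No measurement at hand explains why the number falls.

As far as these compounds go, it remains open whether the fluorine atoms or the new place of the chlorine accounts for the step. From the compounds shown here alone, how a phenyl ring carrying a nitrile or an amine would read at this position also remains open.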